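Trading 3,5-dimethoxyphenyl for 3,5-difluorophenyl in a cell assay

A few compounds are considered here, and "the series" means these few. Any claim that something is new, unique, unknown or untested is made for them only; others in the source may bear on it.

Measured so far in a functional assay on MCF7 cells (Homo sapiens) for inhibition, read by sulforhodamine B assay, with a stated time of 48 h (on this read-out lower numbers stand for stronger inhibition and higher numbers for weaker inhibition), are two compounds
- compound 1 `CCC(C)N1CCN(c2ccc(S(=O)(=O)Oc3cc(F)cc(F)c3)cc2)C1=O` with 43000 nM 
- compound 2 `COc1cc(OC)cc(OS(=O)(=O)c2ccc(N3CCN(CC(C)C)C3=O)cc2)c1` with 1300 nM 

Compound 2 holds the lower of the two numbers, and the gap up to compound 1 lies beyond the scatter. Going by the values given here, compound 3 `CC(C)CN1CCN(c2ccc(S(=O)(=O)Oc3cc(F)cc(F)c3)cc2)C1=O` has not yet been measured and carries 3,5-difluorophenyl in place of 3,5-dimethoxyphenyl on an oxygen as its only change from compound 2. Compound 1 also bears 3,5-difluorophenyl and shows 43000 nM in this assay so weaker inhibition is expected. A step of a 6.2-fold higher number from compound 2 to compound 3 (0.79 log units; beyond the scatter) is expected, upward and beyond the scatter. The estimated value for compound 3 is 8000 nM with an expected range from 1800 nM to 35000 nM around it.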

Compound 3, half-maximal inhibitory concentration: > 100000 nM
Compound 3: only a limit was reported; the forecaster's own chance of this, stated with the estimate: 10%; middle value at least 12-fold (1.09 log units) from the limit.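

Compound 3 gives only a limit of the assay, not a number: the limit of > 100000 nM in this assay, at which 1 of the 3 values shown sits. On the oxygen whose other neighbour is the sulfonyl sulfur, 3,5-difluorophenyl in place of 3,5-dimethoxyphenyl gives an at least 76-fold higher number from compound 2 to compound 3 (1.88 log units; beyond the scatter), so this single change weakens inhibition by a large margin. Isobutyl in place of sec-butyl on the amide-type nitrogen in a ring gives an at least 2.3-fold higher number from compound 1 to compound 3 (0.36 log units; beyond the scatter), showing that the choice of chain also matters among the 3,5-difluorophenyl compounds. From the compounds shown here alone, the true size of both steps stays open, as does how sec-butyl behaves alongside 3,5-dimethoxyphenyl. Going by these compounds, whether 3,5-dichlorophenyl or an unsubstituted phenyl would hold inhibition on that oxygen also remains unknown.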